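Cyclohexyl in Place of Isopropyl on a Carbonyl Carbon

The source may hold more compounds than are shown below. What is called first, only, known or untested is meant among the compounds shown, and "the series" means these compounds.

Compound 2 `CC(C)C(=O)OCOC(=O)C1=C(S[C@@H]2CN[C@H](C(=O)Nc3cccc(C(=O)O)c3)C2)[C@H](C)[C@@H]2[C@@H]([C@@H](C)O)C(=O)N12` stands highest of the three compounds measured in an ADME assay on a cell-free system (plasma, Homo sapiens) for metabolic stability, read by LC-MS, with a stated time of 60 min, at 37 degrees C, tested at 50 uM (on this read-out higher numbers stand for a more stable compound and lower numbers for a less stable compound), where compound 2 gives 15%. Compound 3 `CC(C)C(=O)OCOC(=O)C1=C(S[C@@H]2CN[C@H](C(=O)Nc3cccc(C(=O)OCOC(=O)C(C)C)c3)C2)[C@H](C)[C@@H]2[C@@H]([C@@H](C)O)C(=O)N12` gives 8%, and compound 1 `C[C@@H](O)[C@H]1C(=O)N2C3=C(S[C@@H]4CN[C@@H](C4)C(=O)Nc4cccc(c4)C(=O)OCCCCOC3=O)[C@H](C)[C@H]12` gives 4%. Within the data shown here, the one step that can be followed between measured compounds, a number 7 percentage points lower from compound 2 to compound 3 (within the scatter), puts ((isopropylcarbonyl)oxy)methyl in place of hydrogen on an oxygen next to a carbonyl group and stays within the scatter. Compound 4 `C[C@@H](O)[C@H]1C(=O)N2C(C(=O)OCOC(=O)C3CCCCC3)=C(S[C@@H]3CN[C@H](C(=O)Nc4cccc(C(=O)O)c4)C3)[C@H](C)[C@H]12` differs from compound 2 in a single place: cyclohexyl in place of isopropyl on a carbonyl carbon. No measured step alters the group on that carbonyl carbon, so the shown steps bear on it only indirectly; the step from compound 2 to compound 3 worked at the same (isopropylcarbonyl)oxy portion and stayed within the scatter, and nothing larger is expected from enlarging isopropyl to cyclohexyl there. Compound 4 is therefore expected to give about 15% in this assay, with a range from 5% to 30%. The expected step, no change at the digits printed from compound 2 to compound 4 (within the scatter), means no change beyond the scatter.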

Compound 4, percent of the compound remaining: 20%
Estimate against measurement, compound 4: 5 percentage points below, and the stated range covers the measured number.
By their numbers in this assay, from the lowest: compounds 1, 3, 2 and 4 (each within the scatter of the next, the first and the last beyond it).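

In this assay, among these compounds, putting cyclohexyl in place of isopropyl on the carbonyl carbon gives a number 5 percentage points higher from compound 2 to compound 4 (within the scatter), and this is the first measured step that alters the group at this position. Among the compounds shown here, the position therefore takes the larger, ring-bearing cyclohexyl without a step beyond the scatter, which the earlier compounds, all carrying isopropyl here or lacking this ester, could not show. Nothing at hand accounts for this step or links it to a property of either group.

Still open, as far as these compounds go, is whether a longer chain such as n-hexyl, or a cyclohexyl ring bearing an amine or a carboxylic acid, would read the same on this carbonyl carbon. Also open, from the compounds shown here alone, is whether ((cyclohexylcarbonyl)oxy)methyl would behave alike in compound 3, which carries ((isopropylcarbonyl)oxy)methyl at a second site.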